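A few compounds are considered here, and "the series" means these few. Any claim that something is new, unique, unknown or untested is made for them only; others in the source may bear on it.

Compound 1 `COC(=O)c1cccc(CSc2nc(N)c(C#N)c(-c3ccc(OCC4CC4)cc3)c2C#N)c1`, compound 2 `C=C(C)COc1ccc(-c2c(C#N)c(N)nc(SCC(N)=O)c2C#N)cc1` and compound 3 `N#Cc1c(N)nc(SCC(N)=O)c(C#N)c1-c1ccc(OCC2CCC2)cc1` share one core and differ in their side chains. In an assay on CHO cells for displacement of a labelled ligand from adenosine receptor A3 (Homo sapiens), read by scintillation counting, with a stated time of 120 min, tested at 1 uM (a higher number here means more inhibition at the concentration tested (going by the name of the read-out), a lower number less inhibition), compound 1 gives 4%, compound 2 gives 4% and compound 3 gives 1%. Compound 1 therefore stands level with compound 2 at the digits printed, and the step of a number 3 percentage points lower from compound 2 to compound 3 (within the scatter) lies within the scatter. Compound 4 `CNC(=O)CSc1nc(N)c(C#N)c(-c2ccc(OCC3CC3)cc2)c1C#N` differs from compound 1 by methylcarbamoyl in place of 3-(methoxycarbonyl)phenyl on a saturated chain carbon bound to a sulfur. Within the data shown here, no measured step touches that place; compounds 2 and 3, which carry a carbamoyl group on a saturated chain carbon bound to a sulfur, show inhibition no different from that of compound 1. The chemist therefore expects the step of a number 1 percentage points lower from compound 1 to compound 4 (within the scatter) to remain within the scatter. Compound 4 is estimated at 3%, between -6% and 12%.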

Compound 4, a percentage reported as inhibition, at one concentration (the size of the read-out at that concentration, not a potency): 3%
For compound 4 middle estimate and measured number coincide at the digits printed; measured number inside the range.
By their numbers in this assay, from the lowest: compounds 3, 4, 1 and 2 (each within the scatter of the next).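

In this assay, among these compounds, the first measured change on a saturated chain carbon bound to a sulfur gives a number 1 percentage points lower from compound 1 to compound 4 (within the scatter) and so leaves the reading within the scatter. At this place, exchanging 3-(methoxycarbonyl)phenyl, with its aromatic ring, for methylcarbamoyl, with no ring, gives two compounds that this single-concentration reading cannot tell apart. Nothing available offers an explanation for this result. Going by these compounds, whether a carboxylic acid or an amine at this place would shift the reading stays open. The reading also gives no potency for any of these compounds.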